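Ester variation on two cores in whole-animal inhibition

This account rests on a few compounds, and the source may have more. Where it says the series, first, only, none or still open, it means among the compounds named here.

Measured values in a functional assay on the whole organism (strain CD1) for inhibition, with Mus musculus as the target, with stated times of 15 min and 20 min, at a dose of 10 mg/kg by the subcutaneous route; a lower number here means less inhibition, a higher number more inhibition at the dose given (going by the name of the read-out):
compound 1 `CC(C)(C)OC(=O)/C(C#N)=C/c1ccc(O)c(O)c1` gives 43.4%
compound 2 `CC(C)CCOC(=O)/C(C#N)=C/c1ccc(O)c(O)c1` gives 27.2%
compound 3 `CC(C)(C)OC(=O)/C(C#N)=C/c1cc2ccccc2[nH]1` gives 51.3%

On the core of compound 1 the change isopentyl in place of tert-butyl on an oxygen next to a carbonyl group is measured directly: in this assay the step is a number 16.2 percentage points lower from compound 1 to compound 2 (beyond the scatter). Compound 3 carries a different core, and the difference between the two cores is not broken down here; its value and that of compound 1 lie within the scatter of each other, whereas compound 2 lies beyond the scatter below both.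

Compound 4 `CC(C)CCOC(=O)/C(C#N)=C/c1cc2ccccc2[nH]1` is not yet measured. It stands to compound 3 as compound 2 stands to compound 1, with the same change, (isopentyl in place of tert-butyl on an oxygen next to a carbonyl group), at the same place. Within the data shown here, with only one measured instance of this change, the expectation for compound 4 rests on compound 1 and compound 2, where the step was a number 16.2 percentage points lower from compound 1 to compound 2 (beyond the scatter). A step of similar size, a number 16.3 percentage points lower from compound 3 to compound 4 (beyond the scatter), is expected from compound 3 to compound 4 in this assay. Compound 4 is therefore estimated at 35% in this assay, most likely between 20% and 50%.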

Compound 4, a percentage reported as inhibition, in the whole organism at one dose (the size of the read-out at that dose, not a potency): 46.6%
Compound 4: the middle estimate sits 11.6 percentage points below what was measured; low and high end bracket the measured number.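

On the second core, in this assay, the step for isopentyl in place of tert-butyl is a number 4.7 percentage points lower from compound 3 to compound 4 (within the scatter), so the two esters cannot be told apart there, unlike on the core of compound 1. Set side by side, the two steps cannot be separated: the same change on two cores in this assay, a number 16.2 percentage points lower (beyond the scatter) from compound 1 to compound 2 and a number 4.7 percentage points lower (within the scatter) from compound 3 to compound 4, 11.5 percentage points apart, within the scatter of two such steps. The result is compatible with the change carrying from one core to the other, but two instances do not establish this, do not fix the true size of the step and do not exclude some dependence on the core.

As far as these compounds go, only tert-butyl and isopentyl appear on the oxygen next to the carbonyl group, so the outcome with a methyl group, a longer chain or a carboxylic acid in place of the ester remains open. Also open, from the compounds shown here alone, is whether an amide in place of the ester would keep the inhibition seen at this dose on either core.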